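The source may report more compounds than this note shows. Statements on the series, on what has been measured and on what is new or still open speak of the compounds shown alone.

Measured compounds:
compound 1 `O=C1[C@@H](NS(=O)(=O)c2ccc(-c3ccccn3)s2)CCN1Cc1cc2[nH]cccc-2n1`, 8%
compound 2 `O=C1[C@@H](NS(=O)(=O)c2ccc(-c3ccccn3)s2)CCN1Cc1cc2cc[nH]cc-2n1`, 17%
compound 3 `O=C1[C@@H](NS(=O)(=O)c2nc3cc(Cl)ccc3[nH]2)CCN1Cc1cc2c[nH]ccc-2n1`, 31%

In an assay on isolated protein for inhibition of coagulation factor X (Oryctolagus cuniculus), tested at 1 uM (on this read-out lower numbers stand for less inhibition and higher numbers for more inhibition at the one concentration tested (going by the name of the read-out)), compound 3 gives the highest of the three numbers, with compound 2 nearest below it and compound 1 furthest. Within the data shown here, the one step between single-change neighbours, a number 9 percentage points higher from compound 1 to compound 2 (within the scatter), concerns the group on the saturated chain carbon, not the sulfonyl side, and lies within the scatter. Compound 4 `CC(C)(C)c1ccc(S(=O)(=O)N[C@H]2CCN(Cc3cc4c[nH]ccc-4n3)C2=O)cc1` arises from compound 3 by 4-(tert-butyl)phenyl in place of 5-chloro-1H-benzimidazol-2-yl on a sulfonyl sulfur. Among the measured compounds shown here, no measured step touches this position, so there is no direct guide. Compound 4 is therefore expected near the middle of the measured range, 15%, within 0% to 45%, which means an expected step of a number 16 percentage points lower from compound 3 to compound 4 (beyond the scatter) in this assay.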

Compound 4, a percentage reported as inhibition, at one concentration (the size of the read-out at that concentration, not a potency): 14%
The estimate for compound 4 lay 1 percentage points above the measured number, within the range that was stated.
By their numbers in this assay, from the lowest: compounds 1, 4 and 2 (each within the scatter of the next); then compound 3.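

In this assay, the sulfonyl side proves able to move the number: 4-(tert-butyl)phenyl in place of 5-chloro-1H-benzimidazol-2-yl on a sulfonyl sulfur gives a number 17 percentage points lower from compound 3 to compound 4 (beyond the scatter), whereas the earlier step concerned only the other end of the molecule. This is a single exchange that alters the ring type, the chlorine and the hydrogen-bond donor and acceptor together, so these cannot be told apart. Nothing available explains the drop. On these data alone, it remains open whether 1H-benzimidazol-2-yl without the chlorine would keep the number of compound 3, and how a phenyl carrying an amine or a carboxylic acid in place of tert-butyl would compare.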